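This account rests on a few compounds, and the source may have more. Where it says the series, first, only, none or still open, it means among the compounds named here.

Of the compounds shown here, two have been measured in a functional assay on A-375 cells (Homo sapiens) for cytotoxicity, read by MTT assay, with a stated time of 72 h, tested at 3 uM; a lower number here means less inhibition of growth, a higher number more inhibition of growth at the concentration tested. Compound 1 `N/C(=N\NC(=S)N1CCCC1)c1ccccn1` gives 80% in this assay. Compound 2 `Cc1ccnc(/C(N)=N/NC(=S)N2CCCCC2)c1` gives 69.5% in this assay, the lower of the two numbers; the number for compound 1 stands higher by a margin that lies beyond the usual scatter. Among the measured compounds shown here, compound 1 and compound 2 differ from each other in more than one place, so no single structural step between them can be read off.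

Compound 3 `Cc1ccnc(/C(N)=N/NC(=S)N2CCCC2)c1` has not yet been measured. It differs from compound 2 in one place only: pyrrolidin-1-yl in place of piperidin-1-yl on a thiocarbonyl carbon. Compound 3 thus carries the same five-membered ring on the thiocarbonyl carbon as compound 1, while keeping the rest of compound 2 unchanged.

Because compound 1, with that same ring, gives 80%, a step upward from compound 2 to compound 3 is expected, of size a number 5.5 percentage points higher from compound 2 to compound 3 (within the scatter), though a change within the scatter cannot be ruled out. Compound 3 is therefore estimated at 75% in this assay, with a likely range from 62% to 88%.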

Compound 3, percent growth inhibition at one concentration: 80%
For compound 3 the middle estimate is 5 percentage points below the measured one; low and high end bracket the measured number.
By their numbers in this assay, from the lowest: compound 2; then compounds 1 and 3 (each within the scatter of the next).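

Among the compounds shown here, compounds 2 and 3 provide the first comparison in which only the ring on the thiocarbonyl carbon changes: in this assay, pyrrolidin-1-yl in place of piperidin-1-yl gives a number 10.5 percentage points higher from compound 2 to compound 3 (beyond the scatter) and shows that this position can affect the read-out, a modest step but one that the two earlier compounds, which differ in more than one place, could not isolate. With pyrrolidin-1-yl held constant, methyl in place of hydrogen on an aromatic carbon gives no change at the digits printed from compound 1 to compound 3 (within the scatter) and so shows no effect of this methyl in this pair. Nothing available explains either result.

On these data alone, whether the methyl would also make no difference alongside piperidin-1-yl remains open, as does how a morpholin-4-yl group, an azepan-1-yl group or an open-chain dimethylamino group would read on the same thiocarbonyl carbon. A single tested concentration also leaves open whether compound 1 and compound 3 would separate at lower concentrations.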